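From Methoxycarbonyl to Methylsulfonyl on the Aromatic Ring

This account rests on a few compounds, and the source may have more. Where it says the series, first, only, none or still open, it means among the compounds named here.

In an ADME assay on MT4 cells (Homo sapiens) for cytotoxicity, read by MTT assay, with a stated time of 5 days (on this read-out higher numbers stand for lower toxicity in this test and lower numbers for higher toxicity in this test), compound 1 (`Cc1cc(C)cc(S(=O)(=O)n2c(OCC(=O)Nc3ccccc3Cl)nc3ccccc32)c1`) gives 169000 nM and compound 2 (`COC(=O)c1ccc(NC(=O)COc2nc3ccccc3n2S(=O)(=O)c2cc(C)cc(C)c2)c(Cl)c1`) gives 119000 nM, so the two numbers sit within the usual scatter of each other. Compound 3 (`Cc1cc(C)cc(S(=O)(=O)n2c(OCC(=O)Nc3ccc(S(C)(=O)=O)cc3Cl)nc3ccccc32)c1`) carries methylsulfonyl in place of methoxycarbonyl on an aromatic carbon. Going by the values given here, the one measured step bearing on this change, which put methoxycarbonyl in place of hydrogen, is a 1.4-fold lower number from compound 1 to compound 2 (0.15 log units; within the scatter). Among the compounds with values here, with only that small step as a guide, the expected step in this assay is a 1.1-fold higher number from compound 2 to compound 3 (0.02 log units; within the scatter), nothing beyond the scatter. Compound 3 is estimated at 125000 nM, with an expected range of 55000 nM to 250000 nM.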

Compound 3, half-maximal cytotoxic concentration: > 228000 nM
Compound 3 was reported as a limit; the forecaster's own chance of this, stated with the estimate: 15%; at least 1.8-fold (0.26 log units) between middle value and limit.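

For compound 3, the reading in this assay is a limit, not a number: the limit of > 228000 nM in this assay, at which 1 of the 3 values shown sits. At this position, para to a large group, methylsulfonyl in place of methoxycarbonyl gives an at least 1.9-fold higher number from compound 2 to compound 3 (0.28 log units; that floor lies within the scatter), and methylsulfonyl in place of hydrogen gives an at least 1.3-fold higher number from compound 1 to compound 3 (0.13 log units; that floor lies within the scatter). The earlier compounds shown here tested only methoxycarbonyl here, whereas these floors show that methylsulfonyl brings no lower number than either compound 1 or compound 2. As far as these compounds go, the true size of both steps stays open, and so does the outcome with an amine or a carboxylic acid at this position.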